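Compound 3 after a step within the scatter

The source may report more compounds than this note shows. Statements on the series, on what has been measured and on what is new or still open speak of the compounds shown alone.

From a functional assay on PC-3 cells (Homo sapiens) for cytotoxicity, read by MTT assay, with a stated time of 72 h (on this read-out higher numbers stand for weaker inhibition and lower numbers for stronger inhibition), come these values so far
Compound 1 (`COc1cc2ncnc(Nc3ccc(F)c(Cl)c3)c2cc1NC(=O)N/N=C/c1ccc(C#N)cc1`) gives 36500 nM
Compound 2 (`COc1cc2ncnc(Nc3ccc(F)c(Cl)c3)c2cc1NC(=O)N/N=C/c1ccc(OC)c(OC)c1OC`) gives 29300 nM

Going by the values given here, compound 2 stands level with compound 1, the only other measured compound, and the two lie within the scatter of each other. Compound 3 (`COc1cc2ncnc(Nc3ccc(F)c(Cl)c3)c2cc1NC(=O)N/N=C/c1ccc(O)c(Br)c1`) has no value yet. It departs from compound 2 by one change (3-bromo-4-hydroxyphenyl in place of 2,3,4-trimethoxyphenyl on a carbon with a double bond to nitrogen), 3-bromo-4-hydroxyphenyl in place of 2,3,4-trimethoxyphenyl on a carbon with a double bond to nitrogen. Among the compounds with values here, only one measured step concerns this place, an exchange of 4-cyanophenyl for 2,3,4-trimethoxyphenyl, and it stays inside the scatter. Within the data shown here, no measured compound carries the entering group, so the support is thin. Among the measured compounds shown here, with a 1.2-fold lower number from compound 1 to compound 2 (0.10 log units; within the scatter) as the only guide, in this assay no step beyond the scatter is expected for compound 3, and neither direction is favoured. The estimated step (a 1.2-fold lower number from compound 2 to compound 3 (0.07 log units; within the scatter)) is accordingly small. For compound 3 the expected value is 25000 nM within an estimated range (9000 nM to 70000 nM).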

Compound 3, half-maximal inhibitory concentration: 15300 nM
Compound 3: the middle estimate sits 1.6-fold (0.21 log units) above what was measured; low and high end bracket the measured number.
By their numbers in this assay, from the lowest: compounds 3, 2 and 1 (each within the scatter of the next, the first and the last beyond it).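

In this assay, the group on the carbon with a double bond to nitrogen now produces its first step beyond the scatter: 3-bromo-4-hydroxyphenyl in place of 4-cyanophenyl gives a 2.4-fold lower number from compound 1 to compound 3 (0.38 log units; beyond the scatter), a modest step. Going by these compounds alone, the same group in place of 2,3,4-trimethoxyphenyl gives a 1.9-fold lower number from compound 2 to compound 3 (0.28 log units; within the scatter), so this exchange stays inside the scatter, and only one of the two exchanges shows that this place responds to the group it carries. No measurement is available that would explain this difference between the two exchanges.

The compounds shown leave open whether the modest step belongs to the bromine, to the hydroxyl or to the two together, since both enter at once and no compound here has an aromatic ring carrying only one of them. They also leave open how this place would respond to an aromatic ring bearing an amine or a carboxylic acid, or to a saturated ring in place of the aromatic one.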